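The source may hold more compounds than are shown below. What is called first, only, known or untested is meant among the compounds shown, and "the series" means these compounds.

Of the compounds shown here, three sharing one core have been measured so far. Compound 1 `Nc1sc(-c2ccc(Cl)cc2)c(-c2ccc(Cl)cc2)c1C(=O)N1CCNCC1` carries a piperazin-1-yl on the carbonyl carbon, compound 2 `Nc1sc(-c2ccc(Cl)cc2)c(-c2ccc(Cl)cc2)c1C(=O)NC1CCCC1` a cyclopentylamino, and compound 3 `Nc1sc(-c2ccc(Cl)cc2)c(-c2ccc(Cl)cc2)c1C(=O)NC1CC1` a cyclopropylamino. In a functional assay on A549 cells (Homo sapiens) for inhibition, read by sulforhodamine B assay, with a stated time of 72 h (a higher number here means a weaker inhibitor, a lower number a stronger inhibitor), compound 1 gives 1020 nM, compound 2 gives 6790 nM, and compound 3 gives 1950 nM. Compound 3 thus sits close to compound 1, with a 1.9-fold higher number from compound 1 to compound 3 (0.28 log units; within the scatter), and clearly apart from compound 2, with a 3.5-fold lower number from compound 2 to compound 3 (0.54 log units; beyond the scatter).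

Compound 4 `CC1CN(C(=O)c2c(N)sc(-c3ccc(Cl)cc3)c2-c2ccc(Cl)cc2)CCN1` is the next compound to be tested. Relative to compound 3 it shows (3-methylpiperazin-1-yl in place of cyclopropylamino on a carbonyl carbon). The step that bears most directly on this is the one in the opposite direction between compound 1 and compound 3, a 1.9-fold higher number from compound 1 to compound 3 (0.28 log units; within the scatter), which stayed within the scatter. The larger change, a 6.7-fold higher number from compound 1 to compound 2 (0.82 log units; beyond the scatter), concerns the cyclopentylamino and is less relevant here. Since a piperazin-1-yl and a cyclopropylamino gave nearly the same number, and compound 4 returns to a ring of that kind with an added methyl, no step beyond the scatter is expected from compound 3 to compound 4 in this assay: the estimated step is a 1.8-fold lower number from compound 3 to compound 4 (0.25 log units; within the scatter). Compound 4 is therefore expected to give about 1100 nM, within a range from 400 nM to 3000 nM.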

Compound 4, half-maximal inhibitory concentration: 4930 nM
Beside the measured number, compound 4's estimate is 4.5-fold (0.65 log units) below it; measured number above the stated range.
By their numbers in this assay, from the lowest: compounds 1 and 3 (each within the scatter of the next); then compounds 4 and 2 (each within the scatter of the next).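

Among these compounds, compound 4 is the first test of an addition to the piperazin-1-yl ring, and in this assay a single methyl on a saturated ring carbon already gives a step beyond the scatter (a 4.8-fold higher number from compound 1 to compound 4 (0.68 log units; beyond the scatter)). The earlier near-match of piperazin-1-yl and cyclopropylamino therefore does not extend to every six-membered ring on this carbonyl carbon: 3-methylpiperazin-1-yl stands apart from cyclopropylamino (a 2.5-fold higher number from compound 3 to compound 4 (0.40 log units; beyond the scatter)) and within the scatter of cyclopentylamino (a 1.4-fold lower number from compound 2 to compound 4 (0.14 log units; within the scatter)). No measurement shown here offers an account of what the methyl does at this position.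

The compounds shown leave open whether an ethyl or a hydroxymethyl on the same ring carbon would follow the methyl of compound 4 or return towards the unsubstituted ring of compound 1. From the compounds shown here alone, it also remains open whether a 4-methylpiperazin-1-yl or a morpholin-4-yl on the carbonyl carbon would stay within the scatter of compound 1 or fall with compound 4.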